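A Hydroxylated Side Chain Tested for Maximal Response

The compounds below may be only part of what the source reports. "The series", "measured", "known", "first", "only" and "open" are said of these compounds alone.

compound 1 `Cc1nc(C#Cc2ccc(C(=O)N[C@H](C)C(C)(C)O)nc2)cs1` — 66.6%
compound 2 `C[C@@H](NC(=O)c1ccc(C#Cc2cccc(F)c2)nn1)C(C)(C)O` — 70.2%
compound 3 `CCCNC(=O)c1ccc(C#Cc2cccc(F)c2)cn1` — 65.9%

Of the compounds shown here, three have so far been read in a functional assay on HEK293 cells for positive allosteric modulation of metabotropic glutamate receptor 5 (Rattus norvegicus), read by fluorescence and calcium flux; a lower number here means a smaller maximal response, a higher number a larger maximal response. Compound 3, whose amide carries a plain propyl chain, gives 65.9%. Its number is the smallest of the three, but the gap to compound 1 and the gap to compound 2 both fall within the usual scatter of this kind of measurement, so the three maximal responses cannot be told apart with confidence.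

Compound 4 `CC(C)(O)CCNC(=O)c1ccc(C#Cc2cccc(F)c2)cn1` has not yet been measured. It keeps the whole of compound 3 except for one change: 1-hydroxy-1-methylethyl in place of methyl on a saturated chain carbon, two bonds along the chain from an amide-type nitrogen. The resulting chain resembles the hydroxylated chains carried by compound 1 and compound 2. In this assay compound 1 gives 66.6%, and compound 2 gives 70.2%.

Since those two hydroxylated chains sit within the scatter of compound 3, no step beyond the scatter is expected, and the estimated step of a number 2.1 percentage points higher from compound 3 to compound 4 (within the scatter) is accordingly small. Compound 4 is therefore expected to reach about 68%, with a plausible range from 58% to 78%.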

Compound 4, largest response reached (reported as efficacy), in percent of the reference or control that the assay uses: 61.9%
Compound 4: the middle estimate sits 6.1 percentage points above what was measured; the measured number falls inside the stated range.
By their numbers in this assay, from the lowest: compounds 4, 3, 1 and 2 (each within the scatter of the next).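

Read in this assay, the change from the propyl chain to the 3-hydroxy-3-methylbutyl chain gives a number 4 percentage points lower from compound 3 to compound 4 (within the scatter), and this is the first pair in the set that differs in only one place. It shows that, on a saturated chain carbon, two bonds along the chain from an amide-type nitrogen, 1-hydroxy-1-methylethyl can take the place of methyl, bringing in a hydrogen-bond donor and a hydrogen-bond acceptor, without a maximal response that can be told apart from that of the propyl amide. Nothing available here offers an explanation for this result.

Within the data shown here, what a plain 3-methylbutyl chain, a longer chain, an amine or a carboxylic acid would give at this place stays open, so the single pair cannot separate any contribution of the hydroxyl from that of the added carbons. Also open, from the compounds shown here alone, is whether the same change would give a similar step on the cores of compound 1 and compound 2, and whether the response of compound 4 would hold in any read-out other than maximal response.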